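The compounds below may be only part of what the source reports. "The series", "measured", "known", "first", "only" and "open" are said of these compounds alone.

The study concerns two measured compounds and one still awaiting measurement, all tested in a functional assay on HL-60 cells (Homo sapiens), read by calcium flux; on this read-out higher numbers stand for an effect only at larger amounts of compound and lower numbers for an effect already at smaller amounts. Compound 1, `COc1ccc(Cc2cc(-c3cccs3)nn(CC(=O)Nc3ccc(Br)cc3)c2=O)cc1`, was found to give only a limit of the assay and no number in this assay, namely > 50000 nM. Compound 2, `Cc1cc(Cc2cccc(Cl)c2)c(=O)n(CC(=O)Nc2ccc(Br)cc2)n1`, likewise gives in this assay only a limit of the assay, > 50000 nM. Going by the values given here, compound 2 therefore stands, together with compound 1, at the limit of > 50000 nM in this assay, at which 2 of the 2 values shown sit, so that no number and no step between the two can be stated; both values show the same thing, an effect not reached within the tested range.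

The unmeasured compound 3, `Cc1cc(Cc2ccc(C#N)cc2)c(=O)n(CC(=O)Nc2ccc(Br)cc2)n1`, is derived from compound 2 by a single change: 4-cyanophenyl in place of 3-chlorophenyl on a saturated chain carbon bound to an aromatic carbon. Since compound 2 gives only a limit in this assay, the expected step from compound 2 to compound 3 cannot be set against a measured number; the expectation is that no change beyond the scatter will appear, the estimated step being a step that the limit leaves unreadable from compound 2 to compound 3. On that basis compound 3 is expected to give about 60000 nM in this assay, within a range from 15000 nM to 300000 nM, most likely again as a limit rather than a number.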

Compound 3, half-maximal effective concentration: > 50000 nM
Compound 3 ended at the assay's limit; the forecaster's own chance of this, stated with the estimate: 85%; the middle value lies beyond the limit too.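

In this assay compound 3 gives > 50000 nM, which is a limit of the assay. Compound 2 also gives only a limit, so no step from 3-chlorobenzyl to 4-cyanobenzyl can be read between compound 2 and compound 3: the limit of > 50000 nM in this assay, at which 3 of the 3 values shown sit.

The compounds shown leave open what number any of them would reach in this assay, and whether these two groups differ at all.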